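This account rests on a few compounds, and the source may have more. Where it says the series, first, only, none or still open, it means among the compounds named here.

Compound 3 `CCc1ccc(N/N=C2\CCC(C)n3c2ncc(C(=O)O)c3=O)cc1` carries an ethyl group on an aromatic carbon. In a functional assay on the whole organism for inhibition, with Rattus norvegicus as the target (on this read-out higher numbers stand for an effect only at larger amounts of compound and lower numbers for an effect already at smaller amounts), compound 3 gives only a limit of the assay, > 1000 umol/kg. For comparison, compound 2 `COc1ccc(N/N=C2\CCC(C)n3c2ncc(C(=O)O)c3=O)cc1`, with a methoxy group at that place, gives 7.6 umol/kg in this assay. Compound 1 `CC1CC/C(=N\Nc2ccc(O)cc2)c2ncc(C(=O)O)c(=O)n21`, with a hydroxy group, gives only a limit, > 100 umol/kg. Compound 4 `CC1CC/C(=N\Nc2ccc(-c3ccccc3)cc2)c2ncc(C(=O)O)c(=O)n21` changes the same place again: phenyl in place of ethyl on an aromatic carbon. The measured steps that touch this position are an at least 130-fold higher number from compound 2 to compound 3 (2.11 log units; beyond the scatter) and a step that the two limits leave unreadable from compound 1 to compound 3, and the smaller one, an at least 13-fold lower number from compound 1 to compound 2 (1.11 log units; beyond the scatter), went the other way. None of them exchanges ethyl for phenyl, so the expected direction is open. The estimate for compound 4 is 500 umol/kg, expected between 50 umol/kg and 5000 umol/kg. This estimate means an expected step of an at least 2.0-fold lower number from compound 3 to compound 4 (0.30 log units; that floor lies within the scatter).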

Compound 4, dose for 50% inhibition: > 100 umol/kg
Compound 4 was reported as a limit (the forecaster's own chance of this, stated with the estimate: 60%); the middle value is on the limit's open side.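

Putting phenyl in place of methoxy gives an at least 13-fold higher number from compound 2 to compound 4 (1.11 log units; beyond the scatter) in this assay. Phenyl therefore joins ethyl and hydroxy: of the four groups shown at this place, only methoxy gives a measured number rather than a limit. The steps from compound 1 and from compound 3 to compound 4 cannot be read, with a limit at each end.

On these data alone, it remains open whether an ethoxy group or an amine at this place would also give a measured number. As far as these compounds go, how much of compound 1, compound 3 or compound 4 would reach the effect also stays unknown.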